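The source may report more compounds than this note shows. Statements on the series, on what has been measured and on what is new or still open speak of the compounds shown alone.

Of the compounds shown here, three of one shared core have been tested in a functional assay on HepG2 cells (Homo sapiens) for antiproliferative activity, read by MTT assay, with a stated time of 48 h; a higher number here means a weaker inhibitor, a lower number a stronger inhibitor. Compound 1 `Cc1ccccc1-n1nncc1CN1C(=O)C2(C(C#N)=C(N)Oc3c2c2nc4ccccc4nc2c2ccccc32)c2ccccc21` reaches only the limit of the assay, giving > 50000 nM. Compound 2 `N#CC1=C(N)Oc2c(c3nc4ccccc4nc3c3ccccc23)C12C(=O)N(Cc1cnnn1-c1ccc(Br)cc1)c1ccccc12` likewise gives only a limit, > 50000 nM. Between them stands a step that the two limits leave unreadable from compound 1 to compound 2, a step the two limits leave unreadable in size. Among the compounds with values here, compound 3 `N#CC1=C(N)Oc2c(N)cc3nc4ccccc4nc3c2C12C(=O)N(Cc1cnnn1-c1cccc(C(F)(F)F)c1)c1ccccc12` is the one compound with a number: in this assay compound 3 gives 15800 nM, and it thus stands at the only real value among the three, since the other two sit at the limit of > 50000 nM in this assay, at which 2 of the 3 values shown sit.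

Compound 4 `N#CC1=C(N)Oc2c(N)cc3nc4ccccc4nc3c2C12C(=O)N(Cc1cnnn1-c1ccc([N+](=O)[O-])cc1[N+](=O)[O-])c1ccccc12` follows from compound 3 by one change: 2,4-dinitrophenyl in place of 3-(trifluoromethyl)phenyl on an aromatic nitrogen. Within the data shown here, no measured step bears on this change, because the only counted step, a step that the two limits leave unreadable from compound 1 to compound 2, cannot be read in size. The expectation therefore rests on compound 3 alone. For compound 4 the step of a 1.3-fold higher number from compound 3 to compound 4 (0.10 log units; within the scatter) is estimated to lie within the scatter, with no direction expected. Compound 4 is estimated to give 20000 nM in this assay, within a range of 6000 nM to 50000 nM.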

Compound 4, half-maximal inhibitory concentration: 18400 nM
Compound 4: the middle estimate sits 1.1-fold (0.04 log units) above what was measured; low and high end bracket the measured number.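

In this assay, within the data shown here, the exchange of 3-(trifluoromethyl)phenyl for 2,4-dinitrophenyl on the aromatic nitrogen of the five-membered ring is a 1.2-fold higher number from compound 3 to compound 4 (0.07 log units; within the scatter), and this is the first step at this position whose size can be read. On the core shared by compound 3 and compound 4, this position therefore accepts two differently substituted phenyl groups with no readable difference, even though the entering group brings hydrogen-bond acceptors that the leaving group lacks and has more heavy atoms. Nothing measured here explains why these two groups read alike.

The compounds shown leave open whether an amine, a carboxylic acid or a longer alkyl chain in place of the phenyl ring on this nitrogen would move the number beyond the scatter. Also open, going by these compounds, is how the group on this nitrogen acts on the core of compound 1, since both values on that core are limits and the step between compound 1 and compound 2 cannot be read.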